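Benzyloxyphenyl imines: moving the second hydroxyl

This account rests on a few compounds, and the source may have more. Where it says the series, first, only, none or still open, it means among the compounds named here.

Measured so far:
compound 1 `Cc1cccc(/C=N/c2ccc(OCc3ccccc3)cc2)c1O`: 15500 nM
compound 2 `Oc1ccc(O)c(/C=N/c2ccc(OCc3ccccc3)cc2)c1`: 1230 nM

Both numbers come from an assay on isolated protein for inhibition of Amine oxidase [flavin-containing] B (Homo sapiens), read by fluorescence and Amplex Red, with stated times of 15 min and 20 min; on this read-out lower numbers stand for stronger inhibition and higher numbers for weaker inhibition. Within the data shown here, compound 2 stands lowest of the two, the only step being a 13-fold lower number from compound 1 to compound 2 (1.10 log units; beyond the scatter). Compound 3 `Oc1ccc(/C=N/c2ccc(OCc3ccccc3)cc2)c(O)c1` is not yet measured; it differs from compound 2 by 2,4-dihydroxyphenyl in place of 2,5-dihydroxyphenyl on a carbon with a double bond to nitrogen. Among the measured compounds shown here, no measured step moves one hydroxyl between positions: the single step from compound 1 to compound 2 changes both substituents at once and so bears only loosely on this change. In this assay compound 3 is therefore expected to sit near compound 2, with a step of about a 1.5-fold higher number from compound 2 to compound 3 (0.17 log units; within the scatter) that need not exceed the scatter, giving an estimate of 1800 nM within 500 nM to 6500 nM.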

Compound 3, half-maximal inhibitory concentration: 6780 nM
Estimate against measurement, compound 3: 3.8-fold (0.58 log units) below; the measured number lies above the stated range.
By their numbers in this assay, from the lowest: compound 2; then compound 3; then compound 1.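

In this assay, the arrangement of the hydroxyls on a carbon with a double bond to nitrogen matters on its own: 2,4-dihydroxyphenyl in place of 2,5-dihydroxyphenyl gives a 5.5-fold higher number from compound 2 to compound 3 (0.74 log units; beyond the scatter) with the same atoms present. Against 2-hydroxy-3-methylphenyl, 2,4-dihydroxyphenyl gives only a 2.3-fold lower number from compound 1 to compound 3 (0.36 log units; beyond the scatter), so a second hydroxyl alone does not reproduce the lower number of compound 2. No available evidence bears on this difference.

As far as these compounds go, whether a methoxy group or an amine in place of the second hydroxyl would keep that lower number remains open.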